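This account rests on a few compounds, and the source may have more. Where it says the series, first, only, none or still open, it means among the compounds named here.

Measured so far:
- compound 1 `OC[C@H]1OC(n2cnc3c(SCc4ccccc4)nccc32)[C@H](O)[C@@H]1O` — 30%
- compound 2 `[N-]=[N+]=Nc1nccc2c1ncn2[C@H]1C[C@H](O)[C@@H](CO)O1` — 13%
- compound 3 `[O-][n+]1ccc2c(c1)ncn2[C@H]1C[C@H](O)[C@@H](CO)O1` — a limit, < 5%

In a functional assay on EL4 cells (Mus musculus) for inhibition, tested at 100 uM (a higher number here means more inhibition at the concentration tested (going by the name of the read-out), a lower number less inhibition), compound 1 gives 30%, the highest of the two numbers shown. Compound 2 gives 13%, a gap that lies beyond the scatter of this kind of measurement. For compound 3 this assay reports only a limit, < 5%, so it is not a number to set against the other two (the limit of < 5% in this assay, at which 1 of the 3 values shown sits).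

The unmeasured compound 4 `OC[C@H]1OC(n2cnc3c(Cl)nccc32)[C@H](O)[C@@H]1O` is built from compound 1 by a single change: chloro in place of benzylsulfanyl on an aromatic carbon. The benzylsulfanyl group of compound 1 is the largest substituent among the compounds shown, and the two compounds that carry a small group at that part of the core, compound 2 and compound 3, sit lower. On that slim basis a drop is expected, so that the estimated step of a number 16 percentage points lower from compound 1 to compound 4 (beyond the scatter) goes downward by more than the scatter. Compound 4 is therefore expected to give about 14%, with a likely range from 4% to 28%.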

Compound 4, a percentage reported as inhibition, at one concentration (the size of the read-out at that concentration, not a potency): < 5%
Compound 4: a limit, no number (the forecaster's own chance of this, stated with the estimate: 25%); at least 9 percentage points between middle value and limit.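

Among these compounds, the step is a number at least 25 percentage points lower from compound 1 to compound 4 (beyond the scatter), and it is the first comparison here in which only the group on the aromatic carbon next to the ring nitrogen changes while the rest of the core stays the same. This pair shows that the inhibition seen with compound 1 does not survive the exchange of benzylsulfanyl for chloro at this place. In this assay compound 4 gives < 5%, which is a limit and not a number, so the full size of the step stays unknown because of that limit: the limit of < 5% in this assay, at which 2 of the 4 values shown sit.

The exchange removes the sulfur and the aromatic ring together, so the compounds shown cannot tell which of the two matters. A methylsulfanyl group, which keeps the sulfur without the ring, or a benzylamino group, which keeps the ring without the sulfur, would separate them.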